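The compounds below may be only part of what the source reports. "The series", "measured", "known", "first", "only" and "open" are said of these compounds alone.

Measured compounds:
compound 1, `COc1cc(-c2cc(/C=C/C(=O)c3ccc(N)cc3)[nH]n2)cc(OC)c1OC`, -93%
compound 2, `COc1ccc(-c2cc(/C=C/C(=O)c3ccc(N)cc3)[nH]n2)cc1OC`, -85%
compound 3, `COc1cc(C(=O)/C=C/c2cc(-c3cc(OC)c(OC)c(OC)c3)n[nH]2)cc(OC)c1OC`, -100%

All three were tested in a functional assay on UO-31 cells (Homo sapiens) for cytotoxicity, read by sulforhodamine B assay, with a stated time of 48 h, tested at 100 uM; on this read-out higher numbers stand for a weaker effect at the one concentration tested and lower numbers for a stronger effect. Compound 1 gives -93%, and compound 2 gives -85%; the step of a number 8 percentage points higher from compound 1 to compound 2 (within the scatter) is the change (hydrogen in place of methoxy on an aromatic carbon). Compound 3 gives -100%; its number lies within the scatter of that of compound 1 and beyond the scatter of that of compound 2. The difference between the core of compound 3 and the core of compound 1 is not broken down here.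

Compound 4, `COc1ccc(-c2cc(/C=C/C(=O)c3cc(OC)c(OC)c(OC)c3)[nH]n2)cc1OC`, is not yet measured in this assay. It differs from compound 3 by hydrogen in place of methoxy on an aromatic carbon, the same change that turns compound 1 into compound 2. Since that earlier step was within the scatter, the step from compound 3 to compound 4 is expected to be of similar small size, a number 7 percentage points higher from compound 3 to compound 4 (within the scatter), resting on the value of compound 3, -100%. Compound 4 is therefore estimated at -93%, between -100% and -78%.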

Compound 4, a percentage reported as activity, at one concentration (the size of the read-out at that concentration, not a potency): -93%
For compound 4 middle estimate and measured number coincide at the digits printed; low and high end bracket the measured number.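

In this assay, putting hydrogen in place of methoxy on an aromatic carbon gives a number 7 percentage points higher from compound 3 to compound 4 (within the scatter), and the two cores can be set side by side: the same change on two cores in this assay, a number 8 percentage points higher (within the scatter) from compound 1 to compound 2 and a number 7 percentage points higher (within the scatter) from compound 3 to compound 4, 1 percentage points apart, within the scatter of two such steps. The change therefore carries from the core of compound 1 to the core of compound 3 with no difference that can be told apart, and on neither core does it move the read-out beyond the scatter. This does not show that the change is without effect at lower concentrations, since each value is a read-out at a single concentration and not a potency, and two cores do not establish that it would behave the same way on any other core in the series.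

The compounds shown leave open whether a hydroxy group, a chlorine atom or a longer chain such as ethoxy in place of that methoxy would give a step of the same size. They also leave open what a replacement of the amine on the core of compound 1 by a carboxylic acid would do.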